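Decyl to phenyl swap on the ring nitrogen of compound 2

This account rests on a few compounds, and the source may have more. Where it says the series, first, only, none or still open, it means among the compounds named here.

Compound 1 `CCCCCCCCCCn1cc(Cn2cnc3nc(-c4ccccc4)cc(C(F)(F)F)c3c2=O)nn1`: 8.16 ug/mL
Compound 2 `CCCCCCCCCCn1cc(Cn2c(C)nc3nc(-c4ccccc4)cc(C(F)(F)F)c3c2=O)nn1`: 6.2 ug/mL

In a functional assay on U-937 cells (Homo sapiens) for cytotoxicity, read by MTT assay, with a stated time of 24 h (a higher number here means a weaker inhibitor, a lower number a stronger inhibitor), compound 2 holds the lowest of the two numbers, with compound 1 nearest, but the step of a 1.3-fold lower number from compound 1 to compound 2 (0.12 log units; within the scatter) is within the scatter, so the two compounds are not separable. Compound 3 `Cc1nc2nc(-c3ccccc3)cc(C(F)(F)F)c2c(=O)n1Cc1cn(-c2ccccc2)nn1` differs from compound 2 by phenyl in place of decyl on an aromatic nitrogen. Among the measured compounds shown here, no measured step touches this ring nitrogen; the single step from compound 1 to compound 2 concerns another position and gives no guidance. The expectation for compound 3 is therefore wide, with a modest move to a higher number, a 1.9-fold higher number from compound 2 to compound 3 (0.29 log units; within the scatter). Compound 3 is estimated at 12 ug/mL, range 4 ug/mL to 40 ug/mL.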

Compound 3, half-maximal inhibitory concentration: > 200 ug/mL
Compound 3: only a limit was reported; the forecaster's own chance of this, stated with the estimate: 15%; middle value at least 16-fold (1.22 log units) from the limit.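

In this assay, the ring nitrogen bearing the decyl chain proves sensitive to substitution: phenyl in place of decyl gives an at least 32-fold higher number from compound 2 to compound 3 (1.50 log units; beyond the scatter). Among the compounds shown here, the earlier methyl in place of hydrogen change, at another position, stayed within the scatter, so this is the first change with a large effect. Compound 3 carries a limit and not a number: the limit of > 200 ug/mL in this assay, at which 1 of the 3 values shown sits.

On these data alone, whether the step follows from losing the decyl chain or from gaining the phenyl ring stays open. A hexyl chain or a benzyl group on this aromatic nitrogen would separate the two.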